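Methoxy Additions and Tolerance in Vero Cells

A few compounds are considered here, and "the series" means these few. Any claim that something is new, unique, unknown or untested is made for them only; others in the source may bear on it.

Among the measured compounds shown here, compound 3 `COc1ccc(-c2nc3cc(C(F)(F)F)ccc3[nH]2)cc1` is the only one of three measured compounds with a plain number in an ADME assay on Vero cells (Chlorocebus sabaeus) for cytotoxicity; a lower number here means that less compound is tolerated, a higher number that more compound is tolerated: compound 3 gives 15000 nM. Compound 1 `COc1ccc(-c2nc3cc(C(F)(F)F)ccc3[nH]2)c(OC)c1` gives > 100000 nM, which is a limit of the assay. Compound 2 `COc1ccc(-c2nc3cc(C(C)=O)ccc3[nH]2)c(OC)c1` gives > 100000 nM, also a limit. Going from compound 3 to compound 1 means (methoxy in place of hydrogen on an aromatic carbon), and the step is an at least 6.6-fold higher number from compound 3 to compound 1 (0.82 log units; beyond the scatter). From compound 1 to compound 2 the change is acetyl in place of trifluoromethyl, and the step is a step that the two limits leave unreadable from compound 1 to compound 2. The difference between the cores of compound 2 and compound 3 is not broken down here. Compound 4 `COc1ccc(-c2nc3cc(C(C)=O)ccc3[nH]2)c(OC)c1OC` is not yet measured; it arises from compound 2 by methoxy in place of hydrogen on an aromatic carbon, the same kind of change as from compound 3 to compound 1, though here the new group sits ortho to two methoxy groups and meta to a large group rather than ortho to a large group and meta to a methoxy group. Since compound 2 already sits at the limit of > 100000 nM in this assay, at which 2 of the 3 values shown sit, compound 4 is expected to remain there. The expected step is a step that the limit leaves unreadable from compound 2 to compound 4. The estimate for compound 4 in this assay is 150000 nM, between 60000 nM and 400000 nM.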

Compound 4, half-maximal cytotoxic concentration: > 100000 nM
Compound 4 was reported as a limit; the forecaster's own chance of this, stated with the estimate: 80%; the middle value does not contradict the limit.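

No step can be read from compound 2 to compound 4: in this assay both are reported only as limits. The compounds shown leave open whether the added methoxy changes tolerance at all, since neither compound has a plain number.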